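Replacing a ring-bound amide with an open hydroxyalkyl chain

The source may hold more compounds than are shown below. What is called first, only, known or untested is meant among the compounds shown, and "the series" means these compounds.

Measured compounds:
- compound 1, `CC(C)(C)c1ccc(C(=O)N2CCC3(CC2)C(=O)N(CC(=O)NCCCN)CN3c2ccccc2)cc1`, 4200 nM
- compound 2, `CC1CCCN(C(=O)CN2CN(c3ccccc3)C3(CCN(C(=O)c4ccc(C(C)(C)C)cc4)CC3)C2=O)C1`, 12000 nM
- compound 3, `CC(C)(C)c1ccc(C(=O)N2CCC3(CC2)C(=O)N(CC(=O)N2CCCC(CO)C2)CN3c2ccccc2)cc1`, 8200 nM

All three share one core and differ only in the group attached to the carbonyl carbon at the end of the side chain. In an assay on HEK293 cells for displacement of a labelled ligand from NPC1-like intracellular cholesterol transporter 1 (Homo sapiens) (a lower number here means a stronger inhibitor, a higher number a weaker inhibitor), compound 3 gives 8200 nM, which is the second highest of the three numbers; its nearest neighbour is compound 2, and its furthest is compound 1, with both gaps within the scatter.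

Compound 4, `CC(C)(C)c1ccc(C(=O)N2CCC3(CC2)C(=O)N(CC(=O)NCCCCO)CN3c2ccccc2)cc1`, has not yet been measured. Its change is (4-hydroxybutyl)amino in place of 3-(hydroxymethyl)piperidin-1-yl on a carbonyl carbon. Within the data shown here, two measured steps bear on this. The step of a 2.0-fold higher number from compound 1 to compound 3 (0.29 log units; within the scatter) shows that swapping an open amino chain for the ring amide moved the number only within the scatter. The step of a 1.5-fold lower number from compound 2 to compound 3 (0.17 log units; within the scatter) shows that adding a hydroxy group to the ring amide likewise stayed within the scatter. Only a 2.9-fold higher number from compound 1 to compound 2 (0.46 log units; beyond the scatter) went beyond it, and that step is modest.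

Compound 4 combines an open chain with a hydroxy group, so no step beyond the scatter is expected in this assay. Compound 4 is therefore estimated at 6000 nM, with a range from 2500 nM to 15000 nM, and the expected step is a 1.4-fold lower number from compound 3 to compound 4 (0.14 log units; within the scatter).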

Compound 4, half-maximal inhibitory concentration: 19200 nM
The estimate for compound 4 lay 3.2-fold (0.51 log units) below the measured number; measured number outside the range, above it.
By their numbers in this assay, from the lowest: compounds 1, 3, 2 and 4 (each within the scatter of the next, the first and the last beyond it).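

In this assay, the group on the carbonyl carbon proves less forgiving than the first three compounds suggested: (4-hydroxybutyl)amino in place of 3-(hydroxymethyl)piperidin-1-yl gives a 2.3-fold higher number from compound 3 to compound 4 (0.37 log units; beyond the scatter), so a hydroxy group on an open chain does not stand in for one on the ring. The two open chains also differ from each other, with hydroxymethyl in place of amino giving a 4.6-fold higher number from compound 1 to compound 4 (0.66 log units; beyond the scatter), the largest step among these compounds, although this change also lengthens the chain. Against compound 2, which carries 3-methylpiperidin-1-yl, the same open chain gives a 1.6-fold higher number from compound 2 to compound 4 (0.20 log units; within the scatter), so these two groups cannot be told apart in this assay.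

No evidence at hand accounts for these differences. Going by these compounds, it remains open whether the end group or the chain length drives the step between the two open chains: (3-hydroxypropyl)amino would put the hydroxy group on a chain as long as that of compound 1, and (4-aminobutyl)amino would put the amino group on a chain as long as that of compound 4.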